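The compounds below may be only part of what the source reports. "The series", "measured", "known", "first", "only" and "open" are said of these compounds alone.

Of the compounds shown here, three built on the same core have been measured in an assay on isolated protein for inhibition of DNA topoisomerase 1 (Homo sapiens), with a stated time of 30 min, tested at 100 uM (a lower number here means a weaker effect, a higher number a stronger effect of the compound at the concentration tested), so far. Compound 1 `Oc1cccc(-c2cc(-c3cccnc3)nc(-c3cccc(Cl)c3)c2)c1` gives 27.6%. Compound 2 `Oc1ccc(-c2cc(-c3ccc(Cl)cc3)nc(-c3cccnc3)c2)cc1` gives 18.8%. Compound 3 `Oc1cccc(-c2cc(-c3ccc(Cl)cc3)nc(-c3cccnc3)c2)c1` gives 2.8%, the lowest of the three numbers: the read-out falls a number 24.8 percentage points lower from compound 1 to compound 3 (beyond the scatter) when 4-chlorophenyl replaces 3-chlorophenyl, and it falls a number 16 percentage points lower from compound 2 to compound 3 (beyond the scatter) when 3-hydroxyphenyl replaces 4-hydroxyphenyl. Both of these steps lie beyond the scatter, and both are modest in size.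

The next compound, compound 4 `Oc1cccc(-c2cc(-c3ccccc3)nc(-c3ccc(Cl)cc3)c2)c1`, is reached from compound 3 by a different kind of change: phenyl in place of pyridin-3-yl on an aromatic carbon. Neither measured step touches this group; the two steps that are known concern the chlorophenyl and the hydroxyphenyl groups, while the pyridin-3-yl group is kept in all three measured compounds. There is therefore no direct guide to the size or direction of the step, and the expectation rests on the low starting point of compound 3. For compound 4 the step of a number 5.2 percentage points higher from compound 3 to compound 4 (within the scatter) is expected to stay within the scatter. Compound 4 is estimated at 8% in this assay, within a range from 0% to 25%.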

Compound 4, a percentage reported as inhibition, at one concentration (the size of the read-out at that concentration, not a potency): 7.1%
Estimate against measurement, compound 4: 0.9 percentage points above; low and high end bracket the measured number.
By their numbers in this assay, from the lowest: compounds 3 and 4 (each within the scatter of the next); then compounds 2 and 1 (each within the scatter of the next).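

Exchanging pyridin-3-yl for phenyl, on an aromatic carbon next to the ring nitrogen, is the first change shown at this position, and in this assay the read-out is a number 4.3 percentage points higher from compound 3 to compound 4 (within the scatter). Going from 1 hydrogen-bond acceptor on this group to 0 therefore leaves no effect that can be told from the scatter in this pair, unlike the steps among the chlorophenyl and hydroxyphenyl isomers, which both lie beyond it. Nothing measured speaks to why the two numbers stay so close.

Because compound 3 at 2.8% and compound 4 at 7.1% both sit at the low end of the numbers shown, the pair leaves open whether the ring nitrogen of pyridin-3-yl counts for more when the chlorophenyl and hydroxyphenyl groups are placed as in compound 1 or compound 2, where the read-out is higher. Also open, going by these compounds, is what this position would give with a different group there, such as a furan ring or a phenyl carrying an amine or a carboxylic acid.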